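Three Piperazines and a Fourth Chloro Variant

This account rests on a few compounds, and the source may have more. Where it says the series, first, only, none or still open, it means among the compounds named here.

Compound 1, `CC(C)N1CCN(Cc2csc(N)c2C(=O)c2ccc(Cl)cc2)CC1`, gives 0%.
Compound 2, `Nc1scc(CN2CCN(c3ccc(F)cc3Cl)CC2)c1C(=O)c1ccc(Cl)cc1`, gives 0%.
Compound 3, `Nc1scc(CN2CCN(c3cccc(Cl)c3)CC2)c1C(=O)c1ccc(Cl)cc1`, gives 0%.

All three were tested in an assay on CHO cells for displacement of a labelled ligand from adenosine receptor A1 (Homo sapiens), read by scintillation counting, with a stated time of 120 min, tested at 10 uM (a lower number here means less inhibition, a higher number more inhibition at the concentration tested (going by the name of the read-out)), and all three give the same number at the digits given. Compound 3 therefore stands level with compound 1 and compound 2; the step of no change at the digits printed from compound 1 to compound 3 (within the scatter) and the step of no change at the digits printed from compound 2 to compound 3 (within the scatter) both lie within the scatter, as does no change at the digits printed from compound 1 to compound 2 (within the scatter). Replacing the isopropyl on the ring nitrogen by either aryl group, or swapping one aryl for another, left the read-out unchanged at the digits given.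

Compound 4, `Nc1scc(CN2CCN(c3cc(Cl)ccc3Cl)CC2)c1C(=O)c1ccc(Cl)cc1`, differs from compound 3 in a single place: chloro in place of hydrogen on an aromatic carbon. The three measured steps all concern changes on the same ring nitrogen of the shared core, and none moved the read-out; the pair compound 2 to compound 3 is the closest in kind, an exchange of one chlorinated aryl group for another, and it too showed nothing beyond the scatter. Adding a second chloro to that aryl group is expected to behave the same way, so the step of no change at the digits printed from compound 3 to compound 4 (within the scatter) is expected to stay within the scatter. Compound 4 is estimated at 0%, with a range from -5% to 12%.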

Compound 4, a percentage reported as inhibition, at one concentration (the size of the read-out at that concentration, not a potency): 0%
Estimate against measurement, compound 4: no gap at the digits printed; measured number inside the range.
By their numbers in this assay, from the lowest: compounds 1, 2, 3 and 4 (each within the scatter of the next).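

Adding a chloro in place of hydrogen on an aromatic carbon, ortho to a large group and para to a chloro group, turns 3-chlorophenyl into 2,5-dichlorophenyl and gives no change at the digits printed from compound 3 to compound 4 (within the scatter) in this assay; this is the only step here that adds a single atom to the aryl ring and leaves the rest of the molecule as it stands. The broader exchanges read the same way, with 2,5-dichlorophenyl in place of 2-chloro-4-fluorophenyl giving no change at the digits printed from compound 2 to compound 4 (within the scatter) and 2,5-dichlorophenyl in place of isopropyl on the ring nitrogen giving no change at the digits printed from compound 1 to compound 4 (within the scatter). No other measurement bears on why the read-out stays the same across these changes.

From the compounds shown here alone, whether an amine or a carboxylic acid on the aryl ring, or a longer chain on the ring nitrogen, would lift the read-out away from this shared level remains open. Also open, going by these compounds, is whether these four compounds would separate at another concentration or in a different assay, as a single shared number at one concentration gives no ranking among them.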